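The source may hold more compounds than are shown below. What is called first, only, known or untested is meant among the compounds shown, and "the series" means these compounds.

Measured compounds:
compound 1 `O=C(N/N=C/C1=C(Cl)c2ccccc2CCC1)c1cccc(I)c1`, in a functional assay (MiaPaCa cells, Homo sapiens) for inhibition, read by sulforhodamine B assay, with a stated time of 48 h (on this read-out lower numbers stand for stronger inhibition of growth and higher numbers for weaker inhibition of growth), compound 1 gives 1600 nM
compound 2 `O=C(N/N=C/C1=C(Cl)c2ccccc2CCC1)c1cccc(C(F)(F)F)c1`, compound 2 gives 5800 nM
compound 3 `Cc1cc2c(cc1C)C(Cl)=C(/C=N/NC(=O)c1cccc(I)c1)CCC2`, compound 3 gives 4300 nM

Compounds 1 and 2 differ by trifluoromethyl in place of iodo on an aromatic carbon and the change gives a 3.6-fold higher number from compound 1 to compound 2 (0.56 log units; beyond the scatter). Compound 3 carries the iodo group on a different core; the difference between the two cores is not broken down here. Compound 4 `Cc1cc2c(cc1C)C(Cl)=C(/C=N/NC(=O)c1cccc(C(F)(F)F)c1)CCC2` is not yet measured; it differs from compound 3 by trifluoromethyl in place of iodo on an aromatic carbon, the same change as from compound 1 to compound 2, at the same kind of place. Among the compounds with values here, the step from compound 3 to compound 4 is expected to resemble the earlier one, namely a 3.0-fold higher number from compound 3 to compound 4 (0.48 log units; beyond the scatter), because the single precedent is a 3.6-fold higher number from compound 1 to compound 2 (0.56 log units; beyond the scatter). On that basis compound 4 is estimated at 13000 nM, with a range from 6000 nM to 30000 nM.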

Compound 4, concentration for 50% growth inhibition: 12200 nM
Compound 4: the middle estimate sits 1.1-fold (0.03 log units) above what was measured; the range from low to high includes it.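

In this assay, trifluoromethyl in place of iodo on the core of compound 3 gives a 2.8-fold higher number from compound 3 to compound 4 (0.45 log units; beyond the scatter). The size of this step carries over between the two cores, with no difference beyond the scatter: the same change on two cores in this assay, a 3.6-fold higher number (0.56 log units; beyond the scatter) from compound 1 to compound 2 and a 2.8-fold higher number (0.45 log units; beyond the scatter) from compound 3 to compound 4, 1.3-fold (0.11 log units) apart, within the scatter of two such steps. Within the data shown here, this rests on only two cores and one exchange of groups at one place, so it does not show that the step would hold on other cores, and it does not explain the step.

Open, on these data alone, is how other groups in place of iodo, such as a nitrile or a methoxy group, would compare on these two cores. Also open, as far as these compounds go, is whether the step persists on a core carrying an amine or a carboxylic acid.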